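The compounds below may be only part of what the source reports. "The series", "measured", "known", "first", "only" and "open" are said of these compounds alone.

Measured so far:
- compound 1 `Cn1c(=O)c(-c2cccc([N+](=O)[O-])c2)nc2ccccc21`: in an assay on cells for activation of Cystic fibrosis transmembrane conductance regulator (Homo sapiens), read by fluorescence, with a stated time of 10 min (a higher number here means that more compound is needed for the effect, a lower number that less compound is needed), compound 1 gives > 10000 nM, a limit of the assay rather than a number.
- compound 2 `C=CCn1c(=O)c(-c2cccc([N+](=O)[O-])c2)nc2ccccc21`: in this assay compound 2 gives 55 nM.

Compound 2 holds the only actual number shown in this assay; the other value is a limit (the limit of > 10000 nM in this assay, at which 1 of the 2 values shown sits). Going by the values given here, the one measured step, an at least 180-fold lower number from compound 1 to compound 2 (2.25 log units; beyond the scatter), concerns the same place as the change now considered: vinyl in place of hydrogen on a saturated chain carbon bound to an aromatic nitrogen.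

Compound 3 `O=c1c(-c2cccc([N+](=O)[O-])c2)nc2ccccc2n1Cc1ccc2ccccc2c1` differs from compound 2 by naphthalen-2-yl in place of vinyl on a saturated chain carbon bound to an aromatic nitrogen. The measured step bears on it only indirectly: it shows that carrying a group on that chain carbon, rather than hydrogen, gave a large drop in the number, but it says nothing about swapping one such group for a larger one. Among the compounds with values here, no measured compound carries an aromatic group at this place, so the expected step of a 1.3-fold higher number from compound 2 to compound 3 (0.10 log units; within the scatter) is held near no change beyond the scatter, with wide uncertainty in either direction. For compound 3 the estimate in this assay is 70 nM, within 15 nM to 400 nM.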

Compound 3, half-maximal effective concentration: 4300 nM
Compound 3: the middle estimate sits 61-fold (1.79 log units) below what was measured; the measured number lies above the stated range.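

At the saturated chain carbon bound to an aromatic nitrogen, the group carried is not interchangeable in this assay: naphthalen-2-yl in place of vinyl gives a 78-fold higher number from compound 2 to compound 3 (1.89 log units; beyond the scatter), so the gain seen with vinyl does not extend to every group placed there. Naphthalen-2-yl in place of hydrogen still gives an at least 2.3-fold lower number from compound 1 to compound 3 (0.36 log units; beyond the scatter), which puts the three groups in the order vinyl, naphthalen-2-yl, hydrogen, from lowest number to highest, with every step beyond the scatter. Compound 1 stands at a limit of the assay and not at a number, so this last step is only a bound: the limit of > 10000 nM in this assay, at which 1 of the 3 values shown sits.

Vinyl and naphthalen-2-yl differ at once in heavy atoms, in aromatic rings and in the double bond outside such rings, so these compounds do not show which of these differences goes with the higher number. Also open, as far as these compounds go, is how the number runs through groups of intermediate kind at this place, such as ethyl, a longer chain, or phenyl, and what an amine or a carboxylic acid would do there.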